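Replacing Nitro with Methyl: Expecting Compound 4

This account rests on a few compounds, and the source may have more. Where it says the series, first, only, none or still open, it means among the compounds named here.

Of the compounds shown here, three sharing one core have been measured in an assay on HEK293 cells for displacement of a labelled ligand from 5-hydroxytryptamine receptor 7 (Rattus norvegicus), with a stated time of 60 min; on this read-out higher numbers stand for weaker inhibition and lower numbers for stronger inhibition. Compound 1 `c1ccc(Cn2cc(-c3ccccc3)c3c2CCNC3)cc1` gives 220 nM. Compound 2 `Clc1ccc(-c2cn(Cc3ccccc3)c3c2CNCC3)cc1Cl` gives 4470 nM, and compound 3 `O=[N+]([O-])c1ccc(-c2cn(Cc3ccccc3)c3c2CNCC3)cc1` gives 450 nM. Compound 3 thus stands second highest of the three numbers, much nearer to compound 1 than to compound 2. Compound 4 `Cc1ccc(-c2cn(Cc3ccccc3)c3c2CNCC3)cc1` has not yet been measured; it differs from compound 3 by methyl in place of nitro on an aromatic carbon. Going by the values given here, two measured steps bear on this change. Swapping phenyl for 3,4-dichlorophenyl gave a 20-fold higher number from compound 1 to compound 2 (1.31 log units; beyond the scatter), a large loss, while introducing the nitro gave a 2.0-fold higher number from compound 1 to compound 3 (0.31 log units; beyond the scatter), a modest loss. Removing the nitro should roughly undo that modest step, and the entering methyl is a group not yet tested on this core; the two substituents tried so far on this ring both raised the number. Compound 4 is therefore expected to land close to compound 1, with a 1.5-fold lower number from compound 3 to compound 4 (0.18 log units; within the scatter). The estimate for compound 4 is 300 nM, with a range from 100 nM to 900 nM.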

Compound 4, inhibition constant: 35 nM
Beside the measured number, compound 4's estimate is 8.6-fold (0.93 log units) above it, outside the stated range (below it).
By their numbers in this assay, from the lowest: compound 4; then compound 1; then compound 3; then compound 2.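

In this assay, the substituents seen earlier on this phenyl ring both raised the number, but methyl on the aromatic carbon para to a large group lowers it, with a 6.3-fold lower number from compound 1 to compound 4 (0.80 log units; beyond the scatter). What matters at this position is therefore which group sits there, not merely whether one does: exchanging nitro for methyl gives a 13-fold lower number from compound 3 to compound 4 (1.11 log units; beyond the scatter), and 4-methylphenyl in place of 3,4-dichlorophenyl gives a 130-fold lower number from compound 2 to compound 4 (2.11 log units; beyond the scatter). No measurement here explains why these groups differ so strongly.

From the compounds shown here alone, it remains open whether the gain belongs to methyl alone or carries over to an ethyl group, a methoxy group or a single chlorine. Compound 2 carries two chlorines, so the share of each in its step cannot be separated.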